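Replacing the urea of compound 2 with an acetamide

The source may hold more compounds than are shown below. What is called first, only, known or untested is meant among the compounds shown, and "the series" means these compounds.

Compound 1 `COc1cccc(NC(=S)NC2CC(C)(C)Oc3ccc(Br)cc32)c1`: 66000 nM
Compound 2 `CC(C)NC(=O)NC1CC(C)(C)Oc2ccc(Cl)cc21`: 62000 nM
Compound 3 `CC1(C)CC(NC(=S)Nc2ccc(C#N)cc2)c2cc(F)ccc2O1`: 11000 nM

Three compounds on the shared core have been run in a functional assay on U-373MG ATCC cells (Homo sapiens) for inhibition, read by MTT assay, with a stated time of 72 h; a higher number here means a weaker inhibitor, a lower number a stronger inhibitor. Compound 2 gives 62000 nM, which places it alongside compound 1, whose value of 66000 nM lies within the scatter of compound 2. Compound 3 is the outlier on the low side, its 11000 nM standing beyond the scatter from compound 2.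

Compound 4 `CC(=O)NC1CC(C)(C)Oc2ccc(Cl)cc21` has not yet been measured in this assay. It differs from compound 2 in one place: methyl in place of isopropylamino on a carbonyl carbon. For the measured compounds named here, no other pair among the measured compounds isolates this change, so the expected size of the step rests only on the three values above, which all sit at high numbers.

Compound 2 to compound 4 is therefore expected to be a modest step toward a higher number, a 1.4-fold higher number from compound 2 to compound 4 (0.14 log units; within the scatter), though one that may well fall within the scatter. Compound 4 is estimated at 85000 nM in this assay, with a plausible range from 30000 nM to 250000 nM.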

Compound 4, half-maximal inhibitory concentration: > 100000 nM
Compound 4 gave a limit, no number; the forecaster's own chance of this, stated with the estimate: 30%; middle value at least 1.1-fold (0.07 log units) away from the limit.
By their numbers in this assay, from the lowest: compound 3; then compounds 2 and 1 (each within the scatter of the next). At a limit, above all of these: compound 4.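

In this assay compound 4 gives > 100000 nM, which is a limit of the assay and not a number. For the compounds shown here, this is the first change in the set that isolates the group on the carbonyl carbon, and putting methyl in place of isopropylamino gives an at least 1.6-fold higher number from compound 2 to compound 4 (0.20 log units; that floor lies within the scatter). Going by these compounds alone, the change did not lower the number, so losing the isopropylamino group brought no visible gain in inhibition, but the reading marks only a floor and the true size of the step stays unknown, and only one compound sits at this ceiling: the limit of > 100000 nM in this assay, at which 1 of the 4 values shown sits.

The compounds shown leave open how a longer chain such as butylamino, or a phenylamino group, would read on the same carbonyl carbon. They also leave open whether any group at this position can bring the number down from that of compound 2.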